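The compounds below may be only part of what the source reports. "The series", "measured", "known", "first", "only" and "open" are said of these compounds alone.

Three compounds share one core and differ only in the group on an aromatic carbon. Compound 1 is `Cc1nc(-c2cccc(C(=O)N3CCCC(C(=O)Nc4ccc(Cl)cc4)C3)c2)no1`, compound 2 is `CC(=O)Nc1cccc(C(=O)N2CCCC(C(=O)Nc3ccc(Cl)cc3)C2)c1` and compound 3 is `O=C(Nc1ccc(Cl)cc1)C1CCCN(C(=O)c2cccc(-c3cccs3)c2)C1`. In an ADME assay on PC-3 cells (Homo sapiens) for cytotoxicity, read by WST assay, tested at 100 uM (on this read-out higher numbers stand for more inhibition at the one concentration tested (going by the name of the read-out) and lower numbers for less inhibition), compound 1 gives 0%, compound 2 gives 4% and compound 3 gives 4%. The three steps between them are all small: a number 4 percentage points higher from compound 1 to compound 2 (within the scatter), a number 4 percentage points higher from compound 1 to compound 3 (within the scatter) and no change at the digits printed from compound 2 to compound 3 (within the scatter). Compound 3 therefore sits level with compound 2, and its gap to compound 1 lies within the scatter, so none of the three can be set apart from the others.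

Compound 4 is `O=C(Nc1ccc(Cl)cc1)C1CCCN(C(=O)c2cccc(-c3cnco3)c2)C1`. The change from compound 3 is 1,3-oxazol-5-yl in place of thiophen-2-yl on an aromatic carbon. Every measured exchange at this same aromatic carbon, whether to acetamido or to thiophen-2-yl, left the cytotoxicity read-out essentially unchanged, so a further exchange there is expected to behave the same way, giving no change at the digits printed from compound 3 to compound 4 (within the scatter). For compound 4 the expected value is 4%, with a range from 0% to 12%.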

Compound 4, a percentage reported as inhibition, at one concentration (the size of the read-out at that concentration, not a potency): 0%
Beside the measured number, compound 4's estimate is 4 percentage points above it; measured number inside the range.
By their numbers in this assay, from the lowest: compounds 1, 4, 2 and 3 (each within the scatter of the next).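

Exchanging thiophen-2-yl for 1,3-oxazol-5-yl on this aromatic carbon keeps a five-membered aromatic ring in place but changes its hetero atoms, and this gives a number 4 percentage points lower from compound 3 to compound 4 (within the scatter) in this assay. Set against the two other groups at this carbon, the oxazole reads the same way, with a number 4 percentage points lower from compound 2 to compound 4 (within the scatter) and no change at the digits printed from compound 1 to compound 4 (within the scatter). All four groups at this position therefore stay within the scatter of one another, and nothing shown gives a reason for this.

The compounds shown leave open whether a group of a different kind on this carbon, such as a primary amine or a carboxylic acid, would also stay within that scatter. They also leave open what a change elsewhere on the shared core, such as replacing the chloro group, would do to this read-out.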